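Removing One Methoxy: No Change in Viability Expected

The source may hold more compounds than are shown below. What is called first, only, known or untested is meant among the compounds shown, and "the series" means these compounds.

Compound 1 `COc1ccc(CCCc2ccc(OC)c(OC)c2)c(O)c1`: 97.9%
Compound 2 `COc1ccc(CCCc2ccc(OC)cc2OC)c(O)c1`: 100%
Compound 3 `COc1ccc(CCCc2ccc(OC)c(OC)c2OC)c(O)c1`: 96.3%

In an ADME assay on RAW264.7 cells (Mus musculus) for cytotoxicity, read by MTT assay, with a stated time of 24 h, tested at 1.25 ug/mL (a higher number here means a weaker effect of the compound at the concentration tested, a lower number a stronger effect), compound 3 gives 96.3%, the lowest of the three numbers, but its gaps to compound 1 and to compound 2 both lie within the scatter, so the three compounds cannot be told apart. Compound 4 `COc1ccc(CCCc2cccc(OC)c2OC)c(O)c1` differs from compound 3 by a single change: hydrogen in place of methoxy on an aromatic carbon. For the measured compounds named here, two measured steps bear on this, each a methoxy in place of hydrogen on an aromatic carbon: a number 1.6 percentage points lower from compound 1 to compound 3 (within the scatter) and a number 3.7 percentage points lower from compound 2 to compound 3 (within the scatter), both within the scatter. The step to compound 4 runs the other way, and a shift no larger than the scatter is expected in this assay, namely a number 1.7 percentage points higher from compound 3 to compound 4 (within the scatter). Compound 4 is therefore expected to give 98%, within a range from 92% to 103%.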

Compound 4, a percentage reported as activity, at one concentration (the size of the read-out at that concentration, not a potency): 99.1%
Compound 4: middle estimate off by 1.1 percentage points, on the low side, and the stated range covers the measured number.
By their numbers in this assay, from the lowest: compounds 3, 1, 4 and 2 (each within the scatter of the next).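

In this assay the new step reads a number 2.8 percentage points higher from compound 3 to compound 4 (within the scatter), so the methoxy para to a large group can give way to hydrogen with no shift beyond the scatter. With this step, each of the three methoxy groups on this ring of compound 3 has been exchanged singly for hydrogen, and none of the exchanges gives a step beyond the scatter. Nothing available here offers a measured explanation for this result. Still open, going by these compounds, is whether an amine or a carboxylic acid at this place would leave the read-out as undisturbed. These compounds also cannot show whether the same holds at higher concentrations.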